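A few compounds are considered here, and "the series" means these few. Any claim that something is new, unique, unknown or untested is made for them only; others in the source may bear on it.

Measured so far in an assay on blood for inhibition of C-X-C chemokine receptor type 3 (Homo sapiens), with a stated time of 30 min; a lower number here means a stronger inhibitor, a higher number a weaker inhibitor:
compound 1, `COCCOc1ncc(-c2nc(C(F)(F)F)sc2N2CCN(C(=O)Cn3cnc4cccnc43)[C@H](C)C2)cn1`: 182 nM
compound 2, `Cc1nc(C)n(CC(=O)N2CCN(c3sc(C(F)(F)F)nc3-c3cnc(OC4CCC4)nc3)C[C@H]2C)n1`: 306 nM

Compound 2 has the higher of the two numbers in this assay, but its gap to compound 1, which differs from it in more than one place, lies within the scatter, so the two compounds cannot be placed in any order on these numbers. Within the data shown here, no pair of measured compounds differing in a single place is available, so the size of a single-point change on this core has not yet been seen.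

Compound 3, `CCOc1ccc(-c2nc(C(F)(F)F)sc2N2CCN(C(=O)Cn3nc(C)nc3C)[C@H](C)C2)cn1`, is the next compound to be measured in this assay. It keeps the core of compound 2 and its amide, and differs only in the aromatic group on the five-membered ring: 6-ethoxypyridin-3-yl in place of 2-(cyclobutyloxy)pyrimidin-5-yl on an aromatic carbon. With nothing in the measured set to calibrate this change, the step is expected to stay within the scatter, in either direction. The estimate for compound 3 is 320 nM, with a range from 130 nM to 800 nM, which corresponds to an expected step of a 1.0-fold higher number from compound 2 to compound 3 (0.02 log units; within the scatter).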

Compound 3, half-maximal inhibitory concentration: 887 nM
Compound 3: the middle estimate sits 2.8-fold (0.44 log units) below what was measured; measured number outside the range, above it.
By their numbers in this assay, from the lowest: compounds 1 and 2 (each within the scatter of the next); then compound 3.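

In this assay, among these compounds, placing 6-ethoxypyridin-3-yl in place of 2-(cyclobutyloxy)pyrimidin-5-yl gives a 2.9-fold higher number from compound 2 to compound 3 (0.46 log units; beyond the scatter), the first single-place step on this core and one that lies beyond the scatter. It shows that the aromatic carbon of the five-membered ring, next to the ring nitrogen, is not indifferent to the group it carries: with the amide and the rest of the core unchanged, this exchange alone gives a modest but readable loss of inhibition. No measurement in hand explains why the number rises.

The change alters two things at once, the six-membered aromatic ring and the alkoxy group on it, so the compounds shown do not tell which of the two accounts for the step, or whether both contribute. On these data alone, a compound with 2-ethoxypyrimidin-5-yl or 6-(cyclobutyloxy)pyridin-3-yl at this position on the same core would separate the two, and whether the same step holds with the other amide of compound 1 also remains open.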